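A few compounds are considered here, and "the series" means these few. Any claim that something is new, unique, unknown or untested is made for them only; others in the source may bear on it.

The compounds in this study share one core and differ in the group attached to the carbonyl carbon and in the group carried on the side chain. In an in vitro ADME assay on microsomes from liver (Homo sapiens) for metabolic stability (a lower number here means slower removal, a higher number faster removal of the compound), compound 1 `CC(C)NC(=O)[C@H]1CC[C@@H](n2/c(=N/C(=O)c3ccc(F)cc3)[nH]c3ccc(CN4CCCCC4)cc32)CC1` gives 302 mL.min-1.g-1. Compound 2 `CC(C)NC(=O)[C@H]1CC[C@@H](n2/c(=N/C(=O)c3cccnc3)[nH]c3ccc(CN4CCC(C(C)(C)O)CC4)cc32)CC1` gives 47 mL.min-1.g-1 in this assay, and compound 3 `CC(C)NC(=O)[C@H]1CC[C@@H](n2/c(=N/C(=O)c3cccc(C#N)c3)[nH]c3ccc(CN4CCC(C(C)(C)O)CC4)cc32)CC1` gives 72 mL.min-1.g-1. Compound 3 thus stands second highest of the three numbers: its nearest neighbour is compound 2, whose number lies within the scatter of it, while compound 1, which differs from compound 3 in two places, gives a number beyond the scatter above it. Going by the values given here, the one step measured between compounds differing in a single place, a 1.5-fold higher number from compound 2 to compound 3 (0.19 log units; within the scatter), concerns the group on the carbonyl carbon. Compound 4 `CC(C)NC(=O)[C@H]1CC[C@@H](n2/c(=N/C(=O)c3ccc(F)c(Cl)c3)[nH]c3ccc(CN4CCC(C(C)(C)O)CC4)cc32)CC1` differs from compound 3 as follows: 3-chloro-4-fluorophenyl in place of 3-cyanophenyl on a carbonyl carbon. Among the compounds with values here, the only comparable step stayed within the scatter, so a change at this carbonyl carbon has not moved the number noticeably so far; the higher number of compound 1, which also carries a different side chain, cannot be tied to one change alone. Compound 4 is therefore expected to give a number close to that of compound 3, estimated as 100 mL.min-1.g-1 with a range from 50 mL.min-1.g-1 to 200 mL.min-1.g-1. The expected step is a 1.4-fold higher number from compound 3 to compound 4 (0.14 log units; within the scatter), within the scatter.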

Compound 4, intrinsic clearance in microsomes: 83 mL.min-1.g-1
Beside the measured number, compound 4's estimate is 1.2-fold (0.08 log units) above it, within the range that was stated.
By their numbers in this assay, from the lowest: compounds 2, 3 and 4 (each within the scatter of the next); then compound 1.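

In this assay, replacing 3-cyanophenyl with 3-chloro-4-fluorophenyl on the carbonyl carbon gives a 1.2-fold higher number from compound 3 to compound 4 (0.06 log units; within the scatter) and so does not separate the two compounds, even though the group that leaves has a nitrile and a hydrogen-bond acceptor and the group that enters has neither. Starting from the pyridin-3-yl group instead, the same 3-chloro-4-fluorophenyl group gives a 1.8-fold higher number from compound 2 to compound 4 (0.25 log units; within the scatter), so all three groups tried at this position, with the side chain held the same, now lie within the scatter of one another, a wider range of rings than the single earlier step could show. Nothing given here explains why the number stays so steady across these groups.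

From the compounds shown here alone, all three of these groups are aromatic rings, so it remains open how this carbonyl carbon would respond to a saturated ring such as cyclohexyl, or to a group carrying an amine or a carboxylic acid. Compound 1 differs from each of the other compounds in two places, so its number cannot be assigned to either place without a pair that differs in the side chain alone.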